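A few compounds are considered here, and "the series" means these few. Any claim that something is new, unique, unknown or untested is made for them only; others in the source may bear on it.

Measured so far:
- Compound 1, `O=C(CSC(=S)N[C@H]1CCOC1=O)Nc1ccccc1F`, in a functional assay on EC9706 cells (Homo sapiens) for cytotoxicity, read by MTT assay, with a stated time of 72 h (on this read-out lower numbers stand for stronger inhibition and higher numbers for weaker inhibition), gives > 128000 nM, a limit of the assay rather than a number.
- Compound 2, `COc1ccc(NC(=O)CSC(=S)N[C@H]2CCOC2=O)cc1`, in this assay gives > 128000 nM, again a limit rather than a number.
- Compound 3, `O=C(CCl)Nc1ccc(C(=O)/C=C/c2ccc(Cl)cc2)cc1`, in this assay gives 8340 nM.

Within the data shown here, compound 3 thus holds the only actual number among the three values shown; the other two results are limits, and the limit of > 128000 nM in this assay, at which 2 of the 3 values shown sit, marks the ceiling at which they sit. Among the measured compounds shown here, no two measured compounds differ in just one place, so no measured step can be read from these data, and nothing about the two limit values can be compared with compound 3 beyond the fact that they are limits.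

Compound 4, `O=C(CCl)Nc1ccc(C(=O)/C=C/c2ccc(Br)cc2)cc1`, is the next compound to be tested. It differs from compound 3 by bromo in place of chloro on an aromatic carbon, para to a large group. For a swap of one halogen for a neighbouring halogen at the same place, the expected step of a 1.0-fold lower number from compound 3 to compound 4 (0.02 log units; within the scatter) is small, with no clear direction, and is not expected to go beyond the usual scatter of repeated measurements. In this assay compound 4 is therefore estimated at 8000 nM, within a range from 3500 nM to 18000 nM.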

Compound 4, half-maximal inhibitory concentration: 10100 nM
Compound 4: middle estimate off by 1.3-fold (0.10 log units), on the low side; the measured number falls inside the stated range.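

In this assay, among these compounds, putting bromo in place of chloro gives a 1.2-fold higher number from compound 3 to compound 4 (0.08 log units; within the scatter), and this is the first step that can be read at all, since the earlier compounds differ from one another in more than one place. At this position, on an aromatic carbon of a six-membered aromatic ring and para to a large group, the measurements therefore do not separate the 4-chlorophenyl compound from the 4-bromophenyl compound. Nothing measured here bears on how either halogen acts at this position, and the one recorded observation, about compounds that sit at an assay limit, does not concern this pair.

Going by these compounds, both groups compared are halogens, so it remains open whether the same position would accept a very different group, such as an amine or a carboxylic acid, with as little effect on the number. Also open, on these data alone, is how much of the activity depends on the chloroacetyl amide shared by compound 3 and compound 4, which a comparison with a plain acetyl group in its place could help to show.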